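Sulfonamide series: 3-methoxyphenyl in place of 3,5-dimethylphenyl

The source may report more compounds than this note shows. Statements on the series, on what has been measured and on what is new or still open speak of the compounds shown alone.

In a functional assay on CHO cells (Homo sapiens) for antiproliferative activity against CHO (Cricetulus griseus), read by sulforhodamine B assay, with a stated time of 48 h (a lower number here means a stronger inhibitor, a higher number a weaker inhibitor), compound 1 `O=C1NCCN1c1ccc(S(=O)(=O)Nc2ccc3[nH]ccc3c2)cc1` reads 1310 nM and compound 2 `COc1cc(NS(=O)(=O)c2ccc(N3CCNC3=O)cc2)cc(OC)c1OC` reads 190 nM in the same test. Compound 3 `Cc1cc(C)cc(NS(=O)(=O)c2ccc(N3CCNC3=O)cc2)c1` stands at 210 nM within the scatter of compound 2, and its number lies under that of compound 1 by a gap beyond the scatter.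

Compound 4 `COc1cccc(NS(=O)(=O)c2ccc(N3CCNC3=O)cc2)c1` is not yet measured. It carries 3-methoxyphenyl in place of 3,5-dimethylphenyl on a sulfonamide nitrogen with the rest of the structure unchanged.

Among the compounds with values here, no measured pair differs in one place only, so no step can be read directly. Compound 3 at 210 nM and compound 2 at 190 nM show two different groups on that nitrogen giving values within the scatter, while compound 1 at 1310 nM goes against this.

A small step of a 1.3-fold higher number from compound 3 to compound 4 (0.12 log units; within the scatter) is expected, towards a higher number but within the scatter. Compound 4 is estimated at 280 nM in this assay with an expected range from 120 nM to 700 nM for this reading.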

Compound 4, half-maximal inhibitory concentration: 330 nM
For compound 4 the middle estimate is 1.2-fold (0.07 log units) below the measured one; the measured number falls inside the stated range.
By their numbers in this assay, from the lowest: compounds 2, 3 and 4 (each within the scatter of the next); then compound 1.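

In this assay, within the data shown here, the exchange of 3,5-dimethylphenyl for 3-methoxyphenyl on a sulfonamide nitrogen gives the first step that can be read directly: a 1.6-fold higher number from compound 3 to compound 4 (0.20 log units; within the scatter). The two groups are therefore not told apart by this test, at least in this one pair. They have the same heavy-atom count, and the hydrogen-bond acceptor counted on 3-methoxyphenyl, absent from 3,5-dimethylphenyl, does not take the step beyond the scatter; no supporting data bear on the reason for this result.

From the compounds shown here alone, whether an amine or a carboxylic acid in place of the methoxy group would give a step beyond the scatter remains open. Also open, going by these compounds, is how this assay responds to changes elsewhere in the shared core, away from the sulfonamide nitrogen.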